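The source may report more compounds than this note shows. Statements on the series, on what has been measured and on what is new or still open speak of the compounds shown alone.

Measured compounds in a functional assay on A549 cells (Homo sapiens) for antiproliferative activity, read by MTT assay, with a stated time of 48 h; a lower number here means a stronger inhibitor, a higher number a weaker inhibitor:
- Compound 1, `O=C(/C=C/c1ccc(/C=C/C(=O)c2cc(Cl)ccc2Cl)o1)NO`: 27100 nM
- Compound 2, `O=C(/C=C/c1ccc(/C=C/C(=O)c2ccc(Cl)cc2)o1)NO`: 98100 nM
- Compound 3, `Cc1ccc(C(=O)/C=C/c2ccc(/C=C/C(=O)NO)o2)cc1`: 48600 nM

Compound 3 stands second highest of the three numbers in this assay. Its nearest neighbour is compound 1, which lies within the scatter of it; its furthest is compound 2, separated by a 2.0-fold lower number from compound 2 to compound 3 (0.31 log units; beyond the scatter), a step made by putting methyl in place of chloro on an aromatic carbon of the shared core.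

Compound 4, `CC(C)c1ccc(C(=O)/C=C/c2ccc(/C=C/C(=O)NO)o2)cc1`, has not yet been measured. It differs from compound 3 in one place: isopropyl in place of methyl on an aromatic carbon. The group sits on an aromatic carbon of a six-membered aromatic ring of carbon only, para to a large group.

Within the data shown here, no measured step concerns a change of this kind. The single step shown, from chloro to methyl, is a different exchange and gives no direct guide to growing methyl into isopropyl. With only that to go on, nothing beyond the scatter is expected in this assay: compound 4 is estimated at 42000 nM, with a range from 15000 nM to 120000 nM, which amounts to an expected step of a 1.2-fold lower number from compound 3 to compound 4 (0.06 log units; within the scatter).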

Compound 4, half-maximal inhibitory concentration: 56700 nM
For compound 4 the middle estimate is 1.4-fold (0.13 log units) below the measured one, within the range that was stated.
By their numbers in this assay, from the lowest: compounds 1, 3, 4 and 2 (each within the scatter of the next, the first and the last beyond it).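

In this assay, growing the group on this aromatic carbon from methyl, with 1 heavy atom, to isopropyl, with 3 heavy atoms, makes no real difference: a 1.2-fold higher number from compound 3 to compound 4 (0.07 log units; within the scatter). So this position, para to a large group, accepts a branched group of that size without a change that can be told from the ordinary spread of repeated measurements. The exchange of chloro for isopropyl also stays small, a 1.7-fold lower number from compound 2 to compound 4 (0.24 log units; within the scatter), while the exchange of chloro for methyl, a 2.0-fold lower number from compound 2 to compound 3 (0.31 log units; beyond the scatter), only just passes beyond the scatter, so replacing chloro here gives at most a modest step, and no separate measurement bears on why the number responds so little.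

Open, as far as these compounds go, is whether a group of a different kind on this same carbon, such as an amine, a carboxylic acid or a methoxy group, would give a step clearly beyond the scatter. Also open, from the compounds shown here alone, is whether a longer chain, such as n-butyl, or a still bulkier branched group, such as tert-butyl, would leave the number as little moved as isopropyl does.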